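Removing the tert-butoxy group from compound 2

The source may report more compounds than this note shows. Statements on the series, on what has been measured and on what is new or still open speak of the compounds shown alone.

Compound 1 `O=[N+]([O-])c1ccc(-c2nnc(SCCCN3CCN(c4nc5ccccc5o4)CC3)o2)cc1` gives 67200 nM
Compound 2 `CC(C)(C)Oc1ccc(-c2nnc(SCCCN3CCN(c4nc5ccccc5o4)CC3)o2)cc1` gives 121000 nM
Compound 3 `c1ccc(-c2nnc(SCCCN3CCN(c4nc5ccccc5o4)CC3)o2)cc1` has not yet been measured

Both values come from a functional assay on HepG2 cells (Homo sapiens) for inhibition, read by MTT assay, with a stated time of 72 h (on this read-out lower numbers stand for stronger inhibition and higher numbers for weaker inhibition), and lie close together. On these numbers, compound 2 stands within the scatter of compound 1, so neither can be ranked ahead of the other. Among the compounds with values here, the one measured step reads a 1.8-fold higher number from compound 1 to compound 2 (0.26 log units; within the scatter) and came with tert-butoxy in place of nitro on an aromatic carbon.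

Compound 3 keeps the shared core but loses the tert-butoxy group: hydrogen in place of tert-butoxy on an aromatic carbon is the difference, in words hydrogen in place of tert-butoxy on an aromatic carbon. Within the data shown here, only the one measured step bears on this change, as it replaced a group with the same tert-butoxy. That step stayed within the scatter, so no step beyond the scatter is expected in this assay, although a single step is thin evidence. The expected step reads a 1.3-fold lower number from compound 2 to compound 3 (0.13 log units; within the scatter) and carries that caution. For compound 3 the estimate is 90000 nM, with an expected range from 40000 nM to 200000 nM.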

Compound 3, half-maximal inhibitory concentration: 102000 nM
Compound 3: the middle estimate sits 1.1-fold (0.05 log units) below what was measured; low and high end bracket the measured number.
By their numbers in this assay, from the lowest: compounds 1, 3 and 2 (each within the scatter of the next).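

In this assay, the change from 4-(tert-butoxy)phenyl to phenyl reads as a 1.2-fold lower number from compound 2 to compound 3 (0.07 log units; within the scatter), and hydrogen in place of nitro reads as a 1.5-fold higher number from compound 1 to compound 3 (0.18 log units; within the scatter). Within the data shown here, until now only two substituted compounds could be compared, but the ring without any substituent now gives a baseline: with the five heavy atoms of tert-butoxy gone, compound 3 stays within the scatter of both compound 1 and compound 2, so neither nitro nor tert-butoxy can be told apart from hydrogen at this aromatic carbon. Nothing available here accounts for this lack of a readable difference.

On these data alone, whether an amine, a carboxylic acid or a fluorine atom on this same aromatic carbon would move the number beyond the scatter remains open. Also open, as far as these compounds go, is whether any change away from this ring, such as a longer chain within the shared core, would separate a compound from these three in this assay.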